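Exchanging the Aryl Group on the Shared Core of Compound 1

This account rests on a few compounds, and the source may have more. Where it says the series, first, only, none or still open, it means among the compounds named here.

Compound 1 `O=C1Nc2ccc(Br)cc2/C1=N/NC(=S)N/N=C/c1c(F)cccc1Cl` was examined in a functional assay on HeLa cells (Homo sapiens) for inhibition, read by MTT assay (a higher number here means a weaker inhibitor, a lower number a stronger inhibitor), where compound 1 gives 1610 nM. For the measured compounds named here, it is the only compound of the three tested for which a number rather than a limit was obtained. Compound 2 `O=C1Nc2ccc(Br)cc2/C1=N/NC(=S)N/N=C/c1ccc2ccccc2c1` reached only a limit, > 50000 nM. Compound 3 `COc1ccc(/C=N/NC(=S)N/N=C2\C(=O)Nc3ccc(Br)cc32)c(OC)c1` likewise reached only a limit, > 50000 nM. The measured picture is therefore dominated by the limit of > 50000 nM in this assay, at which 2 of the 3 values shown sit.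

Compound 4 `O=C1Nc2ccc(Br)cc2/C1=N/NC(=S)N/N=C/c1ccc(Br)cc1` has not yet been measured. It differs from compound 1 by 4-bromophenyl in place of 2-chloro-6-fluorophenyl on a carbon with a double bond to nitrogen. Going by the values given here, no measured pair isolates this change, so the size of the step can only be anticipated from the limits seen for compound 2 and compound 3, both of which carry a different aryl group at the same place. Compound 4 is expected to be a weaker inhibitor than compound 1, with an expected step of a 5.0-fold higher number from compound 1 to compound 4 (0.70 log units; beyond the scatter) beyond the scatter yet short of the limit. Compound 4 is thus estimated at 8000 nM, in a range from 2000 nM to 50000 nM.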

Compound 4, half-maximal inhibitory concentration: 4680 nM
Compound 4: middle estimate off by 1.7-fold (0.23 log units), on the high side, within the range that was stated.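

For the compounds shown here, until this result, every other aryl exchange on the shared core of compound 1 had ended at a limit, so no size could be put on any change at this carbon with a double bond to nitrogen. In this assay, 4-bromophenyl in place of 2-chloro-6-fluorophenyl gives a 2.9-fold higher number from compound 1 to compound 4 (0.46 log units; beyond the scatter), a modest weakening that can be read as a number. Losing the 2-chloro-6-fluorophenyl group therefore does not in itself take a compound to the value shared by compound 2 and compound 3, which is a limit and not a number: the limit of > 50000 nM in this assay, at which 2 of the 4 values shown sit.

The compounds shown do not separate the roles of the chlorine, the fluorine and the bromine in this step. They also leave open how an unsubstituted phenyl or a cyclohexyl group would behave at this place.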